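The compounds below may be only part of what the source reports. "The series", "measured", "known", "first", "only" and "open" are said of these compounds alone.

Values in a physicochemical assay for lipophilicity; a higher number here means a more lipophilic compound, a lower number a more polar compound:
- compound 1 `Cc1nc(-c2cc(C(F)(F)F)ccc2[C@H]2CCOc3cc(S(=O)(=O)Nc4ccncn4)ccc32)co1`: "not determined" (no result reported)
- compound 2 `Cc1nc(-c2cc(C(F)(F)F)ccc2[C@H]2CCOc3cc(S(=O)(=O)Nc4ncc(F)cn4)ccc32)co1`: 2.8

Among the measured compounds shown here, compound 2, at 2.8, carries the only number in this small set, so it cannot yet be ranked against anything. For the measured compounds named here, compound 1 has no result, which leaves no measured step to work from.

The next compound to be measured is compound 3 `Cc1ccc(-c2cc(C(F)(F)F)ccc2[C@H]2CCOc3cc(S(=O)(=O)Nc4ncc(F)cn4)ccc32)cn1`. It differs from compound 2 at one place: 6-methylpyridin-3-yl in place of 2-methyl-1,3-oxazol-4-yl on an aromatic carbon. In words, 6-methylpyridin-3-yl stands in place of 2-methyl-1,3-oxazol-4-yl on an aromatic carbon, ortho to a large group and meta to a trifluoromethyl group. The rest of the structure is unchanged.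

Going by the values given here, with no precedent, the expectation in this assay rests on the structural change alone. The expected change is a number 0.30 log units higher from compound 2 to compound 3 (within the scatter), a small upward step close to the usual scatter. For compound 3 the estimate is 3.1, with an expected range of 2.7 to 3.5.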

Compound 3, distribution coefficient: 2.5
For compound 3 the middle estimate is 0.60 log units above the measured one; measured number below the stated range.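

In this assay, 6-methylpyridin-3-yl in place of 2-methyl-1,3-oxazol-4-yl, on an aromatic carbon ortho to a large group and meta to a trifluoromethyl group, gives a number 0.30 log units lower from compound 2 to compound 3 (within the scatter). Among the compounds shown here, this is the first reading at this position: a six-membered aromatic ring with 1 hetero atom can stand in place of a five-membered aromatic ring with 2 hetero atoms without a step beyond the scatter in this assay. Nothing measured on these compounds offers an explanation for the size of this step.

On these data alone, whether a substituent without a ring at this position, such as an amine, a carboxylic acid or a longer chain, would give a step beyond the scatter stays open. So does whether this step would hold with another part of the structure changed.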